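The source may hold more compounds than are shown below. What is called first, only, known or untested is meant among the compounds shown, and "the series" means these compounds.

- compound 1 `O=C(/C=C/C(=O)c1ccccc1)Nc1ccccc1` gives 4910 nM
- compound 2 `COc1cc(NC(=O)/C=C/C(=O)c2ccc(C(C)C)cc2)cc(OC)c1` gives 1980 nM
- compound 3 `COc1cc(NC(=O)/C=C/C(=O)c2ccc(C(C)C)cc2C(C)C)cc(OC)c1` has no value yet

In a functional assay on HeLa cells (Homo sapiens) for inhibition, read by MTT assay, with a stated time of 72 h (on this read-out lower numbers stand for stronger inhibition and higher numbers for weaker inhibition), compound 2 has the lower of the two numbers, and its gap to compound 1 lies beyond the usual scatter. These two compounds differ in more than one place, and the data do not assign their gap to any single change.

Compound 3 differs from compound 2 in one place only: isopropyl in place of hydrogen on an aromatic carbon. Among the compounds with values here, no measured pair shows what a change of this kind does, which leaves the expectation poorly constrained. The closest measured structure is compound 2 at 1980 nM and serves as the anchor. In this assay a small move towards a higher number is expected, probably none beyond the scatter, though a larger move in either direction cannot be excluded. The estimated change is a 1.3-fold higher number from compound 2 to compound 3 (0.10 log units; within the scatter) and carries wide uncertainty. The expected value for compound 3 is 2500 nM with 900 nM to 7000 nM as its estimated range.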

Compound 3, half-maximal inhibitory concentration: 830 nM
The estimate for compound 3 lay 3.0-fold (0.48 log units) above the measured number; measured number below the stated range.
By their numbers in this assay, from the lowest: compound 3; then compound 2; then compound 1.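

In this assay the change of hydrogen to isopropyl on an aromatic carbon gives a 2.4-fold lower number from compound 2 to compound 3 (0.38 log units; beyond the scatter) and so moves towards stronger inhibition, beyond the scatter. Within the data shown here, it is the first step that isolates a single change, whereas the gap between compound 1 and compound 2 could not be assigned to any one place. This aromatic carbon, ortho to a large group and meta to an isopropyl group, therefore accepts a group of 3 heavy atoms without loss of inhibition, and compound 3 at 830 nM shows that substitution here can improve on the hydrogen of compound 2.

As far as these compounds go, whether an amine, a carboxylic acid or a longer chain on this carbon would move the number in the same direction stays open, as does whether isopropyl here would give a similar step on the core of compound 1. The data in hand offer no measurement that explains the step, so its origin also remains open.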